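From 3-fluorobenzyl to 3-methoxybenzyl: working notes on solubility

This account rests on a few compounds, and the source may have more. Where it says the series, first, only, none or still open, it means among the compounds named here.

In a physicochemical assay for solubility, using the shake flask method, in simulated intestinal fluid, measured as kinetic solubility, with a stated time of 2 h, at 25 degrees C, at pH 6.5 (a higher number here means a more soluble compound, a lower number a less soluble compound), compound 1 `Cc1noc(-c2nc(C)c3c(c2N)C(=O)N(Cc2ccc(C(F)(F)F)cc2)C3=O)n1` gives < 5000 nM as a limit of the assay, not a number. Going by these compounds, compound 2 `Cc1noc(-c2nc(C)c3c(c2N)C(=O)N(Cc2cccc(F)c2)C3=O)n1` likewise gives < 5000 nM as a limit only, so its true position is unknown. The whole reading so far is the limit of < 5000 nM in this assay, at which 2 of the 2 values shown sit, and no measured number exists yet. Going by the values given here, the one measured step is a step that the two limits leave unreadable from compound 1 to compound 2 and offers no size to carry forward.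

Compound 3 `COc1cccc(CN2C(=O)c3c(C)nc(-c4nc(C)no4)c(N)c3C2=O)c1` has methoxy in place of fluoro on an aromatic carbon, meta to a large group, a change counted as methoxy in place of fluoro on an aromatic carbon and covered by no readable step. No direction can be argued from these data, so no step beyond the scatter is expected in this assay and another limit is the likely report. The estimated step is a step that the limit leaves unreadable from compound 2 to compound 3 and it carries little weight. For compound 3 the expected solubility is 3000 nM with an estimated range from 800 nM to 8000 nM as a working figure.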

Compound 3, solubility: < 5000 nM
Compound 3 ended at the assay's limit (the forecaster's own chance of this, stated with the estimate: 80%); the middle value does not contradict the limit.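

No step can be read among compound 1, compound 2 and compound 3, since all three stop at one limit of the assay, not a number: the limit of < 5000 nM in this assay, at which 3 of the 3 values shown sit.

The compounds shown leave open where each true solubility lies, and whether 3-fluorobenzyl and 3-methoxybenzyl differ at all in this assay.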